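A few compounds are considered here, and "the series" means these few. Any claim that something is new, unique, unknown or untested is made for them only; others in the source may bear on it.

Compounds measured so far, in a functional assay on cells for inhibition of growth hormone secretagogue receptor type 1 (Homo sapiens), read by FLIPR and calcium flux; a higher number here means that more compound is needed for the effect, a lower number that less compound is needed:

compound 1, `CC(C)(N)C(=O)N[C@H](COCc1ccccc1Cl)c1nnnn1CCOC(=O)NCCCCO`, 0.45 nM
compound 2, `CC(C)(N)C(=O)N[C@H](COCc1cccc(C(F)(F)F)c1)c1nnnn1CCOC(=O)NCCCCO`, 1.79 nM
compound 3, `Cc1ccccc1COC[C@@H](NC(=O)C(C)(C)N)c1nnnn1CCOC(=O)NCCCCO`, 0.51 nM

Compound 3 sits at the second highest of the three numbers; its nearest neighbour is compound 1, and the two lie within the scatter of each other, while compound 2 is the furthest away. The steps among the measured set are a 4.0-fold higher number from compound 1 to compound 2 (0.60 log units; beyond the scatter), a 1.1-fold higher number from compound 1 to compound 3 (0.05 log units; within the scatter) and a 3.5-fold lower number from compound 2 to compound 3 (0.55 log units; beyond the scatter).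

Compound 4, `Cc1noc(C)c1-c1ccccc1COC[C@@H](NC(=O)C(C)(C)N)c1nnnn1CCOC(=O)NCCCCO`, is not yet measured. It differs from compound 3 in one place: 3,5-dimethyl-1,2-oxazol-4-yl in place of methyl on an aromatic carbon. Among the compounds with values here, of the measured steps, only the one from compound 1 to compound 3 touches that same aromatic carbon, and there the exchange of chloro for methyl stayed within the scatter. The other two steps concern a different pattern on the aromatic ring and a different group, so they bear on this change only loosely. Within the data shown here, no measured pair shows what happens when a five-membered aromatic ring enters at this position, so the expectation rests on thin ground. The account therefore expects, at most, a modest shift in this assay, more likely toward a higher number than a lower one, with a step of a 2.9-fold higher number from compound 3 to compound 4 (0.47 log units; beyond the scatter).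

For compound 4 the estimate in this assay is 1.5 nM, within a range from 0.3 nM to 8 nM.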

Compound 4, half-maximal effective concentration: 1.04 nM
Beside the measured number, compound 4's estimate is 1.4-fold (0.16 log units) above it; low and high end bracket the measured number.
By their numbers in this assay, from the lowest: compounds 1 and 3 (each within the scatter of the next); then compounds 4 and 2 (each within the scatter of the next).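

In this assay, the aromatic carbon that holds chloro in compound 1 and methyl in compound 3 also tolerates a much larger group: with 3,5-dimethyl-1,2-oxazol-4-yl, of 7 heavy atoms and one five-membered aromatic ring, the result is a 2.0-fold higher number from compound 3 to compound 4 (0.31 log units; beyond the scatter), and measured against the chloro group it is a 2.3-fold higher number from compound 1 to compound 4 (0.36 log units; beyond the scatter). The earlier exchange at this carbon stayed within the scatter, whereas both of these steps lie beyond it, so this position does respond to what it carries, though only modestly, and compound 4 still reads 1.04 nM. Nothing in the data at hand accounts for the size of this step.

As far as these compounds go, how a plain phenyl or an unsubstituted 1,2-oxazol-4-yl would read at this carbon remains open, so the step cannot yet be divided between the five-membered ring and its two methyl groups. Also open, from the compounds shown here alone, is how a methoxy group, an amine or a carboxylic acid would read at this same carbon, and so whether the modest step seen here holds for groups of other kinds.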